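Adding a four-membered ring to a benzyl-bearing core

A few compounds are considered here, and "the series" means these few. Any claim that something is new, unique, unknown or untested is made for them only; others in the source may bear on it.

Of the compounds shown here, two have been measured in a functional assay on the whole organism for inhibition, with Rattus norvegicus as the target, in the maximal electroshock model, at a dose of 25 mg/kg by the intraperitoneal route; on this read-out lower numbers stand for less inhibition and higher numbers for more inhibition at the one dose given (going by the name of the read-out). Compound 1, `CN(C)c1ncnc2c1ncn2C`, carries a dimethylamino group on its core; in this assay compound 1 gives 33%. Compound 2, `c1ccc(Cn2cnc3cncnc32)cc1`, carries a benzyl group instead and has only hydrogen where compound 1 holds the dimethylamino group; in this assay compound 2 gives 33%, which is level with compound 1 within the usual scatter of such measurements.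

Compound 3, `c1ccc(Cn2cnc3c(N4CCC4)ncnc32)cc1`, has not yet been measured. It differs from compound 2 in one place: azetidin-1-yl in place of hydrogen on an aromatic carbon.

Compound 1 shows that an amine on that aromatic carbon can go together with the same read-out as hydrogen, as the values of compound 1 and compound 2 show. For that reason the step of a number 7 percentage points higher from compound 2 to compound 3 (within the scatter) is expected to be small, within or only slightly beyond the scatter, in the upward direction if any. Compound 3 is therefore estimated to give 40%, with a range from 15% to 65%.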

Compound 3, a percentage reported as inhibition, in the whole organism at one dose (the size of the read-out at that dose, not a potency): 17%
Beside the measured number, compound 3's estimate is 23 percentage points above it, within the range that was stated.
By their numbers in this assay, from the lowest: compound 3; then compounds 1 and 2 (each within the scatter of the next).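

In this assay, azetidin-1-yl in place of hydrogen on this aromatic carbon gives a number 16 percentage points lower from compound 2 to compound 3 (beyond the scatter) at the one dose given. Within the data shown here, this is the only step here that changes a single place, so it shows that this position is not indifferent to what it carries: on the benzyl-bearing core, the four-membered non-aromatic ring goes with less inhibition than hydrogen. Nothing measured here gives a reason for this step.

Going by these compounds, whether the drop is particular to azetidin-1-yl remains open, as a larger ring such as piperidin-1-yl or an open-chain amine such as butylamino could give a different number at this position on the same core. A single dose also leaves open how the read-out of either compound would change at other doses.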